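Swapping the aryl group on the nitrogen for 6-fluoropyridin-3-yl

The source may hold more compounds than are shown below. What is called first, only, known or untested is meant among the compounds shown, and "the series" means these compounds.

Compound 1 `CCS(=O)(=O)Nc1cc(-c2ccc3ncnc(Nc4ccc(F)cc4)c3c2)cnc1OC`: 3160 nM
Compound 2 `CCS(=O)(=O)Nc1cc(-c2ccc3ncnc(Nc4ccc(OC)c(Cl)c4)c3c2)cnc1OC`: 5620 nM

In a functional assay on HCT-116 cells (Homo sapiens) for cytotoxicity, read by sulforhodamine B assay, with a stated time of 72 h (a higher number here means a weaker inhibitor, a lower number a stronger inhibitor), compound 2 gives 5620 nM, which stands within the scatter of compound 1. Compound 3 `CCS(=O)(=O)Nc1cc(-c2ccc3ncnc(Nc4ccc(F)nc4)c3c2)cnc1OC` carries 6-fluoropyridin-3-yl in place of 3-chloro-4-methoxyphenyl on a nitrogen on an aromatic ring. Within the data shown here, one measured step bears on this change, a 1.8-fold higher number from compound 1 to compound 2 (0.25 log units; within the scatter), where the same place went from 4-fluorophenyl to 3-chloro-4-methoxyphenyl. Among the measured compounds shown here, no measured compound has a ring with a hetero atom there, so the evidence is thin. No step beyond the scatter is therefore expected in this assay. The expected step is a 1.6-fold lower number from compound 2 to compound 3 (0.21 log units; within the scatter). For compound 3 the estimate is 3500 nM, with an expected range from 1200 nM to 10000 nM.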

Compound 3, half-maximal inhibitory concentration: 7620 nM
Compound 3: the middle estimate sits 2.2-fold (0.34 log units) below what was measured; measured number inside the range.
By their numbers in this assay, from the lowest: compounds 1, 2 and 3 (each within the scatter of the next, the first and the last beyond it).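

In this assay, placing a hetero atom in the ring gives a 1.4-fold higher number from compound 2 to compound 3 (0.13 log units; within the scatter), so 6-fluoropyridin-3-yl does not separate from 3-chloro-4-methoxyphenyl. Against 4-fluorophenyl, however, it gives a 2.4-fold higher number from compound 1 to compound 3 (0.38 log units; beyond the scatter), the first modest step beyond the scatter at this place on a nitrogen on an aromatic ring. The data offer no explanation for this step. Still open, going by these compounds, is how a pyrimidin-5-yl ring would read here, and whether an aminomethyl or carboxylic acid group on the ring would move the number in either direction.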